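Methyl to Fluoro on a Shared Core: an Expected Step

A few compounds are considered here, and "the series" means these few. Any claim that something is new, unique, unknown or untested is made for them only; others in the source may bear on it.

Of the compounds shown here, three have been tested in a functional assay on HepG2 cells (Homo sapiens) for inhibition, read by MTT assay, with a stated time of 48 h (on this read-out lower numbers stand for stronger inhibition and higher numbers for weaker inhibition), and a fourth awaits measurement. Compound 1 has the structure `COc1ccc(-n2c(SCc3ccc(C)cc3)nnc2-c2cc(OC)c(OC)c(OC)c2)cc1`, and in this assay compound 1 gives 31600 nM. Compound 2, with the structure `COc1ccc(-n2c(SCc3ccc(F)cc3)nnc2-c2cc(OC)c(OC)c(OC)c2)cc1`, differs from compound 1 in one place, namely (fluoro in place of methyl on an aromatic carbon). In this assay compound 2 gives 35000 nM. That exchange produced a 1.1-fold higher number from compound 1 to compound 2 (0.04 log units; within the scatter).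

Compound 3, with the structure `COc1cc(-c2nnc(SCc3ccc(C)cc3)n2-c2ccc(N(C)C)cc2)cc(OC)c1OC`, carries a different core. Set against compound 1, the difference between the two cores is dimethylamino in place of methoxy on an aromatic carbon. For compound 3 this assay reports only a limit, > 60000 nM, and not a number. The step from the core of compound 1 to that of compound 3 reads an at least 1.8-fold higher number from compound 1 to compound 3 (0.27 log units; that floor lies within the scatter).

Compound 4, with the structure `COc1cc(-c2nnc(SCc3ccc(F)cc3)n2-c2ccc(N(C)C)cc2)cc(OC)c1OC`, has not yet been measured. It differs from compound 3 by fluoro in place of methyl on an aromatic carbon, the same change that separates compound 1 from compound 2, made in the same place on the same kind of ring. In this assay that change is expected to matter little for compound 4, because between the measured pair it gave a 1.1-fold higher number from compound 1 to compound 2 (0.04 log units; within the scatter), and because compound 3 already sits at the limit of > 60000 nM in this assay, at which 1 of the 3 values shown sits. Compound 4 is therefore expected to give 70000 nM, with a plausible range from 40000 nM to 150000 nM. The expected step for compound 4 is a step that the limit leaves unreadable from compound 3 to compound 4, and a limit rather than a number is the most likely outcome.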

Compound 4, half-maximal inhibitory concentration: 26400 nM
Beside the measured number, compound 4's estimate is 2.7-fold (0.42 log units) above it, outside the stated range (below it).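

In this assay, going by these compounds, fluoro in place of methyl gives an at least 2.2-fold lower number from compound 3 to compound 4 (0.35 log units; beyond the scatter), yet compound 3 stands only at a limit of the assay and not at a number, so this step is a floor and its true size is unknown. Set beside the same exchange on the core of compound 1, this result hints that the exchange may not carry over unchanged from one core to the other, but it does not establish that: the same change on two cores in this assay, a 1.1-fold higher number (0.04 log units; within the scatter) from compound 1 to compound 2 and an at least 2.2-fold lower number (0.35 log units; beyond the scatter) from compound 3 to compound 4; the limit leaves it open whether they differ. Read the other way, dimethylamino in place of methoxy gives a 1.3-fold lower number from compound 2 to compound 4 (0.12 log units; within the scatter) when fluoro is present, and this step cannot be firmly matched with its partner either: the same change on two cores in this assay, an at least 1.8-fold higher number (0.27 log units; that floor lies within the scatter) from compound 1 to compound 3 and a 1.3-fold lower number (0.12 log units; within the scatter) from compound 2 to compound 4; the limit leaves it open whether they differ.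

The compounds shown leave open how large the step onto compound 4 really is, and so whether the two cores truly answer differently to the same exchange. They also leave open how either core would respond if the methyl or fluoro on that ring gave way to another group, such as chloro, an amine, a carboxylic acid or a longer chain.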